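A few compounds are considered here, and "the series" means these few. Any claim that something is new, unique, unknown or untested is made for them only; others in the source may bear on it.

The three measured compounds share one core and differ only in the aryl group attached to the hydrazone carbon. Compound 1 `Cn1c(=O)c(=O)n(C2CCCC2)c2nc(N/N=C/c3ccccc3)ncc21` carries a plain phenyl ring, and in a functional assay on PC-3 cells (Homo sapiens) for antiproliferative activity, read by MTT assay (a lower number here means a stronger inhibitor, a higher number a weaker inhibitor), compound 1 gives 48200 nM. Compound 2 `Cn1c(=O)c(=O)n(C2CCCC2)c2nc(N/N=C/c3ccc(O)cc3)ncc21` is reached by an at least 2.0-fold higher number from compound 1 to compound 2 (0.31 log units; beyond the scatter). For compound 2 the assay reports only a limit, > 100000 nM; this is the limit of > 100000 nM in this assay, at which 1 of the 3 values shown sits. Compound 3 `COc1ccc(/C=N/Nc2ncc3c(n2)n(C2CCCC2)c(=O)c(=O)n3C)cc1` gives 26300 nM; it is reached from compound 1 by a 1.8-fold lower number from compound 1 to compound 3 (0.26 log units; within the scatter) and from compound 2 by an at least 3.8-fold lower number from compound 2 to compound 3 (0.58 log units; beyond the scatter). Of the two plain numbers compound 3 holds the lower one, but its gap to compound 1 lies within the scatter, so the two cannot be ordered.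

Compound 4 `Cn1c(=O)c(=O)n(C2CCCC2)c2nc(N/N=C/c3ccccc3Cl)ncc21` differs from compound 3 by 2-chlorophenyl in place of 4-methoxyphenyl on a carbon with a double bond to nitrogen. For the measured compounds named here, none of the measured steps involves a chlorine or a change at this part of the ring; they speak only to a hydroxy or a methoxy. The methoxy step from compound 1 stayed within the scatter, and the hydroxy step went beyond it toward a weaker inhibitor. Going by the values given here, with no direct precedent, compound 4 is expected to sit close to compounds 1 and 3, with a 1.5-fold higher number from compound 3 to compound 4 (0.18 log units; within the scatter) as the expected step. The estimate for compound 4 is 40000 nM, expected to fall between 15000 nM and 110000 nM.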

Compound 4, half-maximal inhibitory concentration: 16300 nM
The estimate for compound 4 lay 2.5-fold (0.39 log units) above the measured number; low and high end bracket the measured number.
By their numbers in this assay, from the lowest: compounds 4, 3 and 1 (each within the scatter of the next, the first and the last beyond it). At a limit, above all of these: compound 2.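

In this assay, for the compounds shown here, chloro in place of hydrogen on the aromatic ring is the first single change from the plain phenyl ring that moves beyond the scatter toward a lower number, giving a 3.0-fold lower number from compound 1 to compound 4 (0.47 log units; beyond the scatter). Set against the 4-methoxyphenyl group, however, the 2-chlorophenyl group gives a 1.6-fold lower number from compound 3 to compound 4 (0.21 log units; within the scatter), so these two groups cannot be ordered, even though only the chlorine-bearing compound clears the scatter against the plain phenyl ring. The 2-chlorophenyl group in place of 4-hydroxyphenyl gives an at least 6.1-fold lower number from compound 2 to compound 4 (0.78 log units; beyond the scatter), and this step is only a bound, as its starting value is a limit and not a number: the limit of > 100000 nM in this assay, at which 1 of the 4 values shown sits.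

From the compounds shown here alone, whether the chlorine itself or its place on the ring matters more stays open, as does what a fluoro, a nitrile or a dimethylamino group on the phenyl ring would give. The cyclopentyl group is common to all the compounds shown, so they do not tell how a longer chain on that part of the shared core would read in this assay.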